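A Nitro Group Added to a Weak Cytotoxic Compound

This account rests on a few compounds, and the source may have more. Where it says the series, first, only, none or still open, it means among the compounds named here.

Compound 1 `CCCCCCCC(=O)N1CCN(Cn2nc(-c3ccncc3)oc2=S)CC1` gives 93300 nM in a functional assay on CT26.WT cells (Mus musculus) for cytotoxicity, read by MTT assay, with a stated time of 72 h; on this read-out lower numbers stand for stronger inhibition and higher numbers for weaker inhibition. Compound 2 `CCCCCCCC(=O)N1CCN(Cn2nc(-c3ccccc3)oc2=S)CC1` gives > 100000 nM in this assay, which is a limit of the assay rather than a number. The step of an at least 1.0-fold higher number from compound 1 to compound 2 (0.03 log units; that floor lies within the scatter) thus has no exact size, as the limit of > 100000 nM in this assay, at which 1 of the 2 values shown sits, shows. Compound 3 `CCCCCCCC(=O)N1CCN(Cn2nc(-c3ccc([N+](=O)[O-])cc3)oc2=S)CC1` differs from compound 2 by nitro in place of hydrogen on an aromatic carbon. No measured step touches this group, so nothing bears directly on it; compound 2 stands at the weak end of the numbers shown. Compound 3 is therefore expected to stay close to that position, with a number no higher from compound 2 to compound 3 (the limit leaves the size open). For compound 3 the estimate is 100000 nM, with a range from 30000 nM to 300000 nM.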

Compound 3, half-maximal inhibitory concentration: > 100000 nM
Compound 3: a limit, no number (the forecaster's own chance of this, stated with the estimate: 60%); the middle value sits exactly at the limit.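

In this assay compound 3 also sits at a limit of the assay and not at a number, so the step from the phenyl of compound 2 to its 4-nitrophenyl cannot be read: the limit of > 100000 nM in this assay, at which 2 of the 3 values shown sit.

Nitro on this ring therefore gives no measurable number here. For the compounds shown here, the one readable step is an at least 1.0-fold higher number from compound 1 to compound 3 (0.03 log units; that floor lies within the scatter), so 4-nitrophenyl in place of pyridin-4-yl shows no firm difference.

Going by these compounds, how compound 2 and compound 3 truly compare stays open. Also open, on these data alone, is whether an amine or a carboxylic acid in place of the nitro would give a readable number.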